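The source may hold more compounds than are shown below. What is called first, only, known or untested is meant among the compounds shown, and "the series" means these compounds.

Measured so far: compound 1 `CCc1ncnc(NC(CC)c2ccc(-c3ccccc3)cc2)c1Cl` gives, in an ADME assay on HEK-293T cells (Homo sapiens) for cytotoxicity, with a stated time of 48 h (on this read-out lower numbers stand for higher toxicity in this test and higher numbers for lower toxicity in this test), > 10000 nM, which is a limit of the assay rather than a number. Compound 2 `CCc1ncnc(NC(C)c2cc3c(cc2O)CCCC3)c1Cl` gives > 10000 nM, likewise a limit. Compound 3 `CCc1ncnc(NC(C)c2ccc3c(c2)N(C(C)=O)CCO3)c1Cl` gives > 10000 nM, again a limit.

Compound 1 therefore stands only at a limit, and the two other values shown sit at the same limit (the limit of > 10000 nM in this assay, at which 3 of the 3 values shown sit). Compound 4 `CCc1ncnc(NC(CC)c2ccc(C(C)(C)C)cc2)c1Cl` differs from compound 1 by tert-butyl in place of phenyl on an aromatic carbon. Within the data shown here, no step between measured compounds is available for this change. The step that the limit leaves unreadable from compound 1 to compound 4 is expected to be none beyond the scatter, because compound 1 already sits at the limit (the limit of > 10000 nM in this assay, at which 3 of the 3 values shown sit). Compound 4 is expected to give 15000 nM, within 8000 nM to 40000 nM, most likely reported once more as a limit.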

Compound 4, half-maximal cytotoxic concentration: > 10000 nM
Compound 4: no number, only a limit; the forecaster's own chance of this, stated with the estimate: 80%; the middle value is on the limit's open side.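

Compound 1 and compound 4 both stand only at a limit in this assay, so no step can be read between them: the limit of > 10000 nM in this assay, at which 4 of the 4 values shown sit.

The compounds shown leave open where each true value lies beyond that limit, and so whether tert-butyl and phenyl differ at all on this read-out.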